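The source may hold more compounds than are shown below. What is called first, only, known or untested is meant among the compounds shown, and "the series" means these compounds.

Series notes. Within the data shown here, in a functional assay on PC-3 cells (Homo sapiens) for antiproliferative activity, read by MTT assay (on this read-out lower numbers stand for stronger inhibition and higher numbers for weaker inhibition), the three compounds measured so far are compound 1 `Cn1c(=O)c(=O)n(C2CCCC2)c2nc(N/N=C/c3ccccc3)ncc21`, compound 2 `Cn1c(=O)c(=O)n(C2CCCC2)c2nc(N/N=C/c3ccc(Cl)cc3)ncc21` and compound 3 `Cn1c(=O)c(=O)n(C2CCCC2)c2nc(N/N=C/c3ccc(F)c(Cl)c3)ncc21`. Compound 1 gives 48200 nM, compound 2 gives 8420 nM and compound 3 gives 8550 nM. Compound 3 thus stands second highest of the three numbers in this assay, within the scatter of compound 2 and well apart from compound 1. The two steps that move the number are a 5.7-fold lower number from compound 1 to compound 2 (0.76 log units; beyond the scatter) and a 5.6-fold lower number from compound 1 to compound 3 (0.75 log units; beyond the scatter); the step of a 1.0-fold higher number from compound 2 to compound 3 (0.01 log units; within the scatter) is flat.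

The next compound, compound 4 `Cn1c(=O)c(=O)n(C2CCCC2)c2nc(N/N=C/c3ccc(C(F)(F)F)cc3)ncc21`, carries the change (4-(trifluoromethyl)phenyl in place of 3-chloro-4-fluorophenyl on a carbon with a double bond to nitrogen). Among the measured compounds shown here, no measured step exchanges one substituted phenyl for another that bears a trifluoromethyl group, so the nearest guides are the two steps from the unsubstituted phenyl of compound 1 and the flat step between compound 2 and compound 3; together these suggest that a further substituted phenyl on the same carbon lands close to where compound 2 and compound 3 already sit. For compound 4 the step is therefore expected to be a 1.0-fold lower number from compound 3 to compound 4 (0.00 log units; within the scatter) in this assay, that is, no change beyond the scatter. Compound 4 is estimated at 8500 nM, with a range from 3000 nM to 25000 nM.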

Compound 4, half-maximal inhibitory concentration: 23600 nM
The estimate for compound 4 lay 2.8-fold (0.44 log units) below the measured number; the measured number falls inside the stated range.
By their numbers in this assay, from the lowest: compounds 2 and 3 (each within the scatter of the next); then compound 4; then compound 1.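

In this assay, the substituted phenyls on the carbon with a double bond to nitrogen do not all sit at one level: trifluoromethyl in place of chloro on an aromatic carbon gives a 2.8-fold higher number from compound 2 to compound 4 (0.45 log units; beyond the scatter), and 4-(trifluoromethyl)phenyl in place of 3-chloro-4-fluorophenyl gives a 2.8-fold higher number from compound 3 to compound 4 (0.44 log units; beyond the scatter), so the flat step between compound 2 and compound 3 does not carry over to this group. Trifluoromethyl in place of hydrogen still gives a 2.0-fold lower number from compound 1 to compound 4 (0.31 log units; beyond the scatter), which shows that a substituent on the phenyl can lower the number by only part of the step seen with chloro, a 5.7-fold lower number from compound 1 to compound 2 (0.76 log units; beyond the scatter). No measurement shown here explains why trifluoromethyl and chloro differ at this position.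

The compounds shown leave open how a methoxy, a nitrile or an amine on the phenyl would compare with chloro and trifluoromethyl, and whether any of these would bring the number below the level of compound 2 and compound 3. They also leave open whether the same order of substituents holds when another part of the shared core is changed, for example with a longer alkyl chain in place of the methyl group.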